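The compounds below may be only part of what the source reports. "The series", "measured", "known", "first", "only" and "open" are said of these compounds alone.

Compound 3, with the structure `Cc1cc(C(=O)N2CCCCc3ccccc32)ccc1CNC(=O)N1CCC[C@H]1C(=S)N(C)C`, stands lowest of the three measured compounds in a functional assay on HEK293 cells for agonist activity at Vasopressin V2 receptor (Homo sapiens), read by a luciferase reporter and cAMP accumulation (a higher number here means that more compound is needed for the effect, a lower number that less compound is needed), where compound 3 gives 3.2 nM. Compound 1, `COC(=O)CNC(=O)NCc1ccc(C(=O)N2CCCCc3ccccc32)cc1C`, gives 37 nM in this assay, and compound 2, `Cc1cc(C(=O)N2CCCCc3ccccc32)ccc1CNC(=O)NCC(=O)N1CCCC1`, gives 100 nM. The two steps that lead to compound 3 are both large: a 12-fold lower number from compound 1 to compound 3 (1.06 log units; beyond the scatter) and a 31-fold lower number from compound 2 to compound 3 (1.49 log units; beyond the scatter), while the step of a 2.7-fold higher number from compound 1 to compound 2 (0.43 log units; beyond the scatter) is modest. Compound 4, `Cc1cc(C(=O)N2CCCCc3ccccc32)ccc1CNC(=O)N1C[C@H](O)C[C@H]1C(=O)N(C)C`, keeps the shared core and the urea, and differs from compound 3 in one place: a group of 11 heavy atoms (7 carbon, 2 nitrogen, 2 oxygen; one five-membered non-aromatic ring with 1 hetero atom) in place of a group of 10 heavy atoms (7 carbon, 2 nitrogen, 1 sulfur; one five-membered non-aromatic ring with 1 hetero atom), on a carbonyl carbon. For the measured compounds named here, no measured pair isolates this exchange of a sulfur-bearing group for an oxygen-bearing one on the ring, nor the added hydroxyl, so the comparison rests on the wide spread seen among compounds 1, 2 and 3. Because of the size of a 31-fold lower number from compound 2 to compound 3 (1.49 log units; beyond the scatter), a move back toward a higher number is expected for compound 4, but smaller than that step, so the expected change is a 3.1-fold higher number from compound 3 to compound 4 (0.49 log units; beyond the scatter). Compound 4 is therefore estimated at 10 nM, within a range from 3 nM to 40 nM.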

Compound 4, half-maximal effective concentration: 2.3 nM
The estimate for compound 4 lay 4.3-fold (0.64 log units) above the measured number; measured number below the stated range.
By their numbers in this assay, from the lowest: compounds 4 and 3 (each within the scatter of the next); then compound 1; then compound 2.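

In this assay the exchange on the carbonyl carbon gives a 1.4-fold lower number from compound 3 to compound 4 (0.14 log units; within the scatter), so at this position the low number of compound 3 does not depend on its sulfur-bearing group: the 2-(dimethylcarbamoyl)-4-hydroxypyrrolidin-1-yl group, which holds no sulfur, serves equally well. That group also keeps the large distance from the open-chain ureas, with a 43-fold lower number from compound 2 to compound 4 (1.64 log units; beyond the scatter) and a 16-fold lower number from compound 1 to compound 4 (1.21 log units; beyond the scatter). No measurement shown here explains these results.

As far as these compounds go, compound 4 differs from compound 3 both in the oxygen that replaces sulfur and in the added hydroxyl, so the effect of each alone stays unknown, and the two could even offset each other. Also open, from the compounds shown here alone, is how the number would respond to an amine in place of that hydroxyl, or to a carboxylic acid in place of the dimethylcarbamoyl group.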